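Bromo in place of fluoro: compound 3 to compound 4

A few compounds are considered here, and "the series" means these few. Any claim that something is new, unique, unknown or untested is made for them only; others in the source may bear on it.

In a functional assay on 786-0 cells (Homo sapiens) for inhibition, read by sulforhodamine B assay, with a stated time of 48 h (on this read-out higher numbers stand for weaker inhibition of growth and lower numbers for stronger inhibition of growth), compound 1 `CCOC(=O)c1nn(-c2ccc(Cl)cc2)c(-c2ccc(F)cc2)c1CNC(C)(C)C` gives > 582000 nM; > 537000 nM (2 entries), which is a limit of the assay and not a number. Compound 2 `CCOC(=O)c1nn(-c2ccc(Cl)cc2)c(-c2ccc(Br)cc2)c1CNC(C)(C)C` gives > 511000 nM; > 476000 nM (2 entries), again only a limit. Going by the values given here, compound 3 `CC(C)(C)NCc1c(C(=O)O)nn(-c2ccc(Cl)cc2)c1-c1ccc(F)cc1` gives 204000 nM, the only actual number in the set. Compound 4 `CC(C)(C)NCc1c(C(=O)O)nn(-c2ccc(Cl)cc2)c1-c1ccc(Br)cc1` has bromo in place of fluoro on an aromatic carbon, para to a large group (bromo in place of fluoro on an aromatic carbon). Among the compounds with values here, no pair of measured compounds shows this exchange as a number, so the expectation in this assay is cautious. The estimated step of a 1.1-fold lower number from compound 3 to compound 4 (0.05 log units; within the scatter) is expected to stay within the usual scatter, with no firm direction. For compound 4 the expected value is 180000 nM, with an estimated range of 90000 nM to 380000 nM.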

Compound 4, concentration for 50% growth inhibition: 542000 nM
The estimate for compound 4 lay 3.0-fold (0.48 log units) below the measured number; measured number outside the range, above it.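

In this assay, going by these compounds alone, the exchange of 4-fluorophenyl for 4-bromophenyl gives a 2.7-fold higher number from compound 3 to compound 4 (0.42 log units; beyond the scatter), the first readable step at this place, and it points to weaker inhibition of growth with bromo. The same exchange between compound 1 and compound 2 cannot be read, as both give only limits of the assay. The entries shown hold no measured property that bears on this step.

On these data alone, whether iodo, methoxy or an amine at this place would continue that direction remains open.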